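Notes on the group bound to the carbonyl carbon

A few compounds are considered here, and "the series" means these few. Any claim that something is new, unique, unknown or untested is made for them only; others in the source may bear on it.

Measured so far in a functional assay on MIA PaCa-2 cells (Homo sapiens) for inhibition, read by MTT assay, with a stated time of 3 days; on this read-out lower numbers stand for stronger inhibition and higher numbers for weaker inhibition:
- compound 1 `CCN1CC(NC(=O)[C@@H]2CCCN(S(=O)(=O)c3ccc(S(=O)(=O)N(CC)CC)cc3)C2)C1`: > 10000 nM
- compound 2 `CCN(CC)S(=O)(=O)c1ccc(S(=O)(=O)N2CCC[C@@H](C(=O)N3CCN(c4nc(C)no4)CC3)C2)cc1`: 200 nM

Compound 1 stands at the limit of this assay; its entry is a limit rather than a number (the limit of > 10000 nM in this assay, at which 1 of the 2 values shown sits). Compound 2 gives a measured number, and the step of an at least 50-fold lower number from compound 1 to compound 2 (1.69 log units; beyond the scatter) replaces (1-ethylazetidin-3-yl)amino with 4-(3-methyl-1,2,4-oxadiazol-5-yl)piperazin-1-yl on the carbonyl carbon.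

Compound 3 `CCN(CC)S(=O)(=O)c1ccc(S(=O)(=O)N2CCC[C@@H](C(=O)N[C@H]3CCN(C(=O)OC(C)(C)C)C3)C2)cc1` differs from compound 1 by 1-(tert-butoxycarbonyl)pyrrolidin-3-yl in place of 1-ethylazetidin-3-yl on an amide-type nitrogen. Among the compounds with values here, the amide-type nitrogen and its hydrogen remain as in compound 1, so the only measured step, from compound 1 to compound 2, bears on it only loosely, as that step exchanged the whole group on the carbonyl carbon. A step in this assay beyond the scatter is therefore not expected with confidence; at most a modest move toward lower numbers is foreseen. Compound 3 is estimated at 6000 nM, range 1500 nM to 30000 nM, which would mean an at least 1.6-fold lower number from compound 1 to compound 3 (0.22 log units; that floor lies within the scatter); a limit in place of a number remains likely.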

Compound 3, half-maximal inhibitory concentration: 170 nM
For compound 3 the middle estimate is 35-fold (1.55 log units) above the measured one; the whole stated range lies above it.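

In this assay, the change on the amide-type nitrogen gives an at least 58-fold lower number from compound 1 to compound 3 (1.76 log units; beyond the scatter), so this position responds strongly even with the nitrogen and its hydrogen retained. A measured number in this series therefore does not depend on replacing the whole group on the carbonyl carbon with 4-(3-methyl-1,2,4-oxadiazol-5-yl)piperazin-1-yl, and the true size of the step remains unknown, as the entry for compound 1 is a limit and not a number: the limit of > 10000 nM in this assay, at which 1 of the 3 values shown sits.

Compound 3 changes the ring and the substituent on the ring nitrogen together, so a pyrrolidin-3-yl carrying a free amine or an ethyl group on that nitrogen would be needed to separate the two. Going by these compounds, the role of the defined stereocentre also remains open, and the opposite stereoisomer of the 1-(tert-butoxycarbonyl)pyrrolidin-3-yl group would address it.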